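Working notes: amine aryl change from compound 1 to compound 4

The source may hold more compounds than are shown below. What is called first, only, known or untested is meant among the compounds shown, and "the series" means these compounds.

Measured compounds:
compound 1 `Cn1c(=O)c(S(=O)(=O)c2ccc(F)cc2F)cc2cnc(Nc3ccc4cc[nH]c4c3)nc21` 5000 nM
compound 2 `Cn1c(=O)c(S(=O)(=O)c2ccccc2)cc2cnc(Nc3ccc4cc[nH]c4c3)nc21` 10000 nM
compound 3 `Cn1c(=O)c(S(=O)(=O)Cc2ccc(F)cc2)cc2cnc(Nc3ccc4[nH]ccc4c3)nc21` 30000 nM

In a functional assay on DU-145 cells (Homo sapiens) for inhibition, read by trypan blue exclusion, with a stated time of 72 h (on this read-out higher numbers stand for weaker inhibition and lower numbers for stronger inhibition), compound 1 gives 5000 nM, the lowest number of the three; compound 2 lies within the scatter of it, while compound 3 lies beyond it. Among the measured compounds shown here, the only single-point step measured, a 2.0-fold higher number from compound 1 to compound 2 (0.30 log units; within the scatter), concerns the group on the sulfonyl sulfur and does not touch the amine side. For the measured compounds named here, compound 3 differs from compound 1 in two places, so its value shows no single step.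

Compound 4 `Cn1c(=O)c(S(=O)(=O)c2ccc(F)cc2F)cc2cnc(Nc3ccc4cccc(O)c4n3)nc21` differs from compound 1 by 8-hydroxyquinolin-2-yl in place of 1H-indol-6-yl on a nitrogen on an aromatic ring. Going by the values given here, no measured step bears on this position, so neither direction is supported by data, and no step beyond the scatter is expected in this assay. Compound 4 is expected to give 8000 nM, with a range of 2000 nM to 40000 nM. That estimate means an expected step of a 1.6-fold higher number from compound 1 to compound 4 (0.20 log units; within the scatter).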

Compound 4, half-maximal inhibitory concentration: 5000 nM
For compound 4 the middle estimate is 1.6-fold (0.20 log units) above the measured one; low and high end bracket the measured number.
By their numbers in this assay, from the lowest: compounds 1, 4 and 2 (each within the scatter of the next); then compound 3.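

In this assay, the amine aryl position now has its first single-point step: 8-hydroxyquinolin-2-yl in place of 1H-indol-6-yl gives no change at the digits printed from compound 1 to compound 4 (within the scatter). At this position, with the 2,4-difluorophenyl sulfonyl group held constant, the indole group is therefore not required to keep this read-out, and the larger 8-hydroxyquinolin-2-yl group leaves it unchanged. No measurement on hand explains this lack of change. Open, going by these compounds, is how quinolin-2-yl without the hydroxy group, or a phenyl carrying a piperazine or a carboxylic acid, would read at this place.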